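Dropping the bromo substituent from a thiosemicarbazone isatin

A few compounds are considered here, and "the series" means these few. Any claim that something is new, unique, unknown or untested is made for them only; others in the source may bear on it.

Measured compounds:
- compound 1 `O=C1C(=O)N(CN2CCN(c3ccnc4cc(Cl)ccc34)CC2)c2cccc(Cl)c21`: 37800 nM
- compound 2 `O=C1C(=O)N(CN2CCN(c3ccnc4cc(Cl)ccc34)CC2)c2cccc(Br)c21`: 15900 nM
- compound 3 `NC(=S)N/N=C1/C(=O)N(CN2CCN(c3ccnc4cc(Cl)ccc34)CC2)c2cccc(Br)c21`: 40400 nM

All three were tested in a functional assay on MDA-MB-468 cells (Homo sapiens) for cytotoxicity, read by sulforhodamine B assay, with a stated time of 48 h; on this read-out lower numbers stand for stronger inhibition of growth and higher numbers for weaker inhibition of growth. Among them compound 3 gives the highest number, 40400 nM, which lies within the scatter of the value of compound 1 but beyond the scatter above that of compound 2. Compound 4 `NC(=S)N/N=C1/C(=O)N(CN2CCN(c3ccnc4cc(Cl)ccc34)CC2)c2ccccc21` has not yet been measured. It differs from compound 3 in one place: hydrogen in place of bromo on an aromatic carbon.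

Among the measured compounds shown here, no measured step removes a halogen outright. The closest comparison is the exchange of one halogen for another at the same aromatic carbon, a 2.4-fold lower number from compound 1 to compound 2 (0.38 log units; beyond the scatter), a modest shift. Taking a halogen away entirely is a different change, so that step is only a loose guide; it suggests that this position can move the number, but not by much.

On this basis compound 4 is expected to give a number close to that of compound 3, perhaps slightly higher, with the step of a 1.4-fold higher number from compound 3 to compound 4 (0.13 log units; within the scatter) estimated as small. The estimate for compound 4 in this assay is 55000 nM, within a range of 22000 nM to 140000 nM.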

Compound 4, concentration for 50% growth inhibition: 20600 nM
Estimate against measurement, compound 4: 2.7-fold (0.43 log units) above, and the stated range ends above it.
By their numbers in this assay, from the lowest: compounds 2, 4, 1 and 3 (each within the scatter of the next, the first and the last beyond it).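

In this assay, taking the bromo away entirely and leaving hydrogen on this aromatic carbon gives a 2.0-fold lower number from compound 3 to compound 4 (0.29 log units; within the scatter). So, among the thiosemicarbazones shown, the two compounds cannot be told apart, and a halogen at this place is not required to reach this level of growth inhibition, whereas the earlier step, a 2.4-fold lower number from compound 1 to compound 2 (0.38 log units; beyond the scatter), showed only an exchange of one halogen for another, in compounds without the thiosemicarbazone. Nothing available explains this result.

On these data alone, whether a methoxy group, an amine or a carboxylic acid on this aromatic carbon would give a number beyond the scatter of compound 4 remains open. As far as these compounds go, it is also open whether hydrogen in place of bromo would leave compound 2, which lacks the thiosemicarbazone, within the scatter as well.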